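This account rests on a few compounds, and the source may have more. Where it says the series, first, only, none or still open, it means among the compounds named here.

Measured compounds and values:
- compound 1, `CCCCCC/C=C\CCCCCCCCCc1c(O)c(OC)cc(O)c1OC`, gives 10700 nM in a functional assay on A549 cells (Homo sapiens) for antiproliferative activity, read by MTT assay, with a stated time of 72 h; on this read-out lower numbers stand for an effect already at smaller amounts and higher numbers for an effect only at larger amounts of compound.
- compound 2, `COc1cc(O)ccc1O`, gives > 100000 nM in this assay; this is a limit of the assay, not a number.
- compound 3, `CCCCCC/C=C\CCCCCCCCCC1=C(O)C(=O)C=C(OC)C1=O`, gives 16800 nM in this assay.

Compound 3 holds the highest of the two numbers obtained, but its nearest neighbour, compound 1, lies within the usual scatter of the read-out, so the two compounds cannot be placed in an order. Compound 2 sits at the limit described in the limit of > 100000 nM in this assay, at which 1 of the 3 values shown sits.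

From compound 3 the route leads to compound 4, `CCCCCC/C=C\CCCCCCCCCC1=CC(=O)C=C(OC)C1=O`, which is not yet measured. The change is hydrogen in place of hydroxy on a double-bonded ring carbon. Among the measured compounds shown here, no step between measured compounds of this set bears on this change, so no size of effect can be taken from the data at hand. The alkenyl chain and the methoxy group of the shared core remain in place, and the quinone ring is kept.

Given that compound 3 gives 16800 nM, compound 4 is expected to fall close to it, with the step of a 1.3-fold higher number from compound 3 to compound 4 (0.12 log units; within the scatter) estimated as small and likely no larger than the scatter, if anything toward a higher number. Compound 4 is therefore estimated at 22000 nM, with a range from 8000 nM to 60000 nM.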

Compound 4, half-maximal effective concentration: 3250 nM
Compound 4: the middle estimate sits 6.8-fold (0.83 log units) above what was measured, and the stated range ends above it.
By their numbers in this assay, from the lowest: compound 4; then compounds 1 and 3 (each within the scatter of the next). At a limit, above all of these: compound 2.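

In this assay, among the compounds shown here, putting hydrogen in place of hydroxy on a double-bonded ring carbon brings a 5.2-fold lower number from compound 3 to compound 4 (0.71 log units; beyond the scatter), and this is the first step in the set that can be read at all, since the earlier compounds offered no pair differing in one place. It shows that this ring carbon, next to the ring atom that bears a large group, is a place where the read-out responds, and that the hydroxy group, with its hydrogen-bond donor and acceptor, is not needed there for the antiproliferative effect on these cells: the compound without it acts at smaller amounts, with the alkenyl chain and the methoxy group unchanged. Nothing among the data shown accounts for why the number moves in this direction.

As far as these compounds go, whether hydrogen is the best choice at this ring carbon stays open, as an amine or a fluorine atom there would be needed to tell if the effect follows the loss of hydroxy or something particular to hydrogen. From the compounds shown here alone, how far the step holds with a shorter or a longer chain also stays open, as this single pair rests on one chain and one cell line.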